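The source may report more compounds than this note shows. Statements on the series, on what has been measured and on what is new or still open speak of the compounds shown alone.

Compound 1, `COc1ccccc1/C=C/S(=O)(=O)Cc1ccc(OC)c([N+](=O)[O-])c1`: 20000 nM
Compound 2, `COc1ccc(OC)c(/C=C/S(=O)(=O)Cc2ccc(OC)c(N)c2)c1`: 750 nM
Compound 3, `COC(=O)CCNc1cc(CS(=O)(=O)/C=C/c2c(OC)cc(OC)cc2OC)ccc1OC`: 1000 nM

In a functional assay on K562 cells (Homo sapiens) for cytotoxicity, read by trypan blue exclusion, with a stated time of 96 h (a lower number here means a stronger inhibitor, a higher number a weaker inhibitor), compound 3 gives 1000 nM, the second highest of the three numbers. Compound 2 stands closest to it, within the scatter, while compound 1 sits far off with a number beyond the scatter. Compound 4, `COc1ccc(C(Nc2cc(CS(=O)(=O)/C=C/c3c(OC)cc(OC)cc3OC)ccc2OC)C(=O)O)cc1`, differs from compound 3 in one place: carboxy(4-methoxyphenyl)methyl in place of 2-(methoxycarbonyl)ethyl on a nitrogen on an aromatic ring. Among the measured compounds shown here, no measured pair shows a comparable change, so the size of the step is uncertain. The account expects only a small move in this assay, if anything toward a higher number, and not clearly beyond the scatter; the expected step from compound 3 is a 1.5-fold higher number from compound 3 to compound 4 (0.18 log units; within the scatter). Compound 4 is thus estimated at 1500 nM, within a range of 500 nM to 5000 nM.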

Compound 4, half-maximal inhibitory concentration: 15 nM
For compound 4 the middle estimate is 100-fold (2.00 log units) above the measured one; the whole stated range lies above it.
By their numbers in this assay, from the lowest: compound 4; then compounds 2 and 3 (each within the scatter of the next); then compound 1.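

The nitrogen on an aromatic ring proved far from indifferent to its substituent: in this assay, carboxy(4-methoxyphenyl)methyl in place of 2-(methoxycarbonyl)ethyl gives a 67-fold lower number from compound 3 to compound 4 (1.82 log units; beyond the scatter). Among the compounds shown here, no earlier compound showed a single change at this place. Nothing at hand explains the size of this step.

The change brings in the carboxylic acid and the aromatic ring together, so the compounds shown leave open which of them goes with the lower number. A benzyl or 2-carboxyethyl group on this nitrogen would separate the two.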